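Compound 4: a smaller group on the same nitrogen

The source may report more compounds than this note shows. Statements on the series, on what has been measured and on what is new or still open speak of the compounds shown alone.

Measured in a functional assay on DU-145 cells (Homo sapiens) for cytotoxicity, read by trypan blue exclusion, with a stated time of 96 h; a lower number here means a stronger inhibitor, a higher number a weaker inhibitor:
- compound 1 `COc1cc(OC)c(/C=C/S(=O)(=O)Nc2ccc(OC)c(F)c2)c(OC)c1` gives 200 nM
- compound 2 `COc1cc(OC)c(/C=C/S(=O)(=O)Nc2ccc(OC)c(N)c2)c(OC)c1` gives 5 nM
- compound 3 `COC(=O)C(C)(C)Nc1cc(NS(=O)(=O)/C=C/c2c(OC)cc(OC)cc2OC)ccc1OC` gives 200 nM

In this assay compound 3 stands level with compound 1, and together they hold the highest number of the three. Compound 4 `COc1cc(OC)c(/C=C/S(=O)(=O)Nc2ccc(OC)c(NCC(=O)O)c2)c(OC)c1` changes compound 3 thus: carboxymethyl in place of 1-(methoxycarbonyl)-1-methylethyl on a nitrogen on an aromatic ring. Going by the values given here, one measured step bears most directly on this: placing a group on that nitrogen of compound 2 gave a 40-fold higher number from compound 2 to compound 3 (1.60 log units; beyond the scatter), a large rise. Compound 4 still carries a group there, so only part of that rise is expected to be undone. The expected step is a 5.0-fold lower number from compound 3 to compound 4 (0.70 log units; beyond the scatter), which is an estimate. For compound 4 the estimated value is 40 nM, with an expected range from 8 nM to 200 nM in this measurement.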

Compound 4, half-maximal inhibitory concentration: 400 nM
The estimate for compound 4 lay 10-fold (1.00 log units) below the measured number, outside the stated range (above it).
By their numbers in this assay, from the lowest: compound 2; then compounds 1, 3 and 4 (each within the scatter of the next).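

In this assay carboxymethyl in place of 1-(methoxycarbonyl)-1-methylethyl on this nitrogen gives a 2.0-fold higher number from compound 3 to compound 4 (0.30 log units; within the scatter) and so the smaller group does not recover the low number of compound 2. Carboxymethyl in place of hydrogen gives an 80-fold higher number from compound 2 to compound 4 (1.90 log units; beyond the scatter) and thus both substituted amines shown lose that low number, while (carboxymethyl)amino in place of fluoro gives a 2.0-fold higher number from compound 1 to compound 4 (0.30 log units; within the scatter) and so does no better than fluoro. No measurement shown gives a reason for this.

Going by these compounds, whether a single methyl on this nitrogen would preserve the number of compound 2 remains open. So does the effect of an acetyl group or a longer chain ending in a carboxylic acid.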